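The source may hold more compounds than are shown below. What is called first, only, known or untested is meant among the compounds shown, and "the series" means these compounds.

Measured so far:
compound 1 `Cn1cc(C2=C(c3nn(CCCn4cncn4)c4ncccc34)C(=O)NC2=O)c2ccccc21`: > 100000 nM, a limit
compound 2 `Cn1cc(C2=C(c3nn(CCCn4cncn4)c4ncccc34)C(=O)N(c3ccccc3)C2=O)c2ccccc21`: > 100000 nM, a limit
compound 3 `Cn1cc(C2=C(c3nn(CCCN4CCCCC4)c4ncccc34)C(=O)N(c3cccc4ccccc34)C2=O)c2ccccc21`: 3180 nM

All three compounds were tested in a functional assay on K562 cells (Homo sapiens) for antiproliferative activity, read by MTT assay, with a stated time of 48 h; on this read-out lower numbers stand for stronger inhibition and higher numbers for weaker inhibition. Compound 1 has no exact number there. Its > 100000 nM is a limit of the assay. Compound 2 also ends at a limit, > 100000 nM. Compound 1 therefore stands at the limit of > 100000 nM in this assay, at which 2 of the 3 values shown sit. Within the data shown here, compound 3 is the only one with a number, 3180 nM.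

Compound 4 `Cn1cc(C2=C(c3n[nH]c4ncccc34)C(=O)NC2=O)c2ccccc21` has not yet been measured. It keeps the core of compound 1 and differs at one place: hydrogen in place of 3-(1H-1,2,4-triazol-1-yl)propyl on an aromatic nitrogen. In words, this is hydrogen in place of 3-(1H-1,2,4-triazol-1-yl)propyl on an aromatic nitrogen.

Among the measured compounds shown here, the only measured step is a step that the two limits leave unreadable from compound 1 to compound 2. It concerns another place and gives no size to carry over. For the measured compounds named here, no measured step isolates the change at the aromatic nitrogen, and compound 3 differs from compound 1 in more than one place. Only a modest, uncertain move toward stronger inhibition is therefore expected in this assay, and compound 4 may well stay at the limit. The estimate amounts to an at least 1.6-fold lower number from compound 1 to compound 4 (0.22 log units; that floor lies within the scatter), an expected step of uncertain size. Compound 4 is expected at 60000 nM. The expected range for compound 4 runs from 10000 nM to 150000 nM.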

Compound 4, half-maximal inhibitory concentration: > 100000 nM
Compound 4: only a limit was reported (the forecaster's own chance of this, stated with the estimate: 55%); at least 1.6-fold (0.22 log units) between middle value and limit.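

In this assay, compound 4 gives > 100000 nM, which is a limit of the assay. Compound 1 and compound 4 both end at a limit, so no step between them can be read: the limit of > 100000 nM in this assay, at which 3 of the 4 values shown sit.

The compounds shown leave open whether hydrogen in place of 3-(1H-1,2,4-triazol-1-yl)propyl on the aromatic nitrogen changes inhibition at all, and which difference sets compound 3 apart at 3180 nM.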